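Pyrazinyl substituent swap and its expected permeability effect

The source may report more compounds than this note shows. Statements on the series, on what has been measured and on what is new or still open speak of the compounds shown alone.

Measured so far in an ADME assay on MDCKII-LE cells (Canis lupus familiaris) for permeability; a lower number here means that the compound crosses the layer more slowly, a higher number that the compound crosses the layer faster:
Compound 1 `Cc1cnc(NC(=O)c2cc(Oc3cnc(C(=O)N(C)C)cn3)c3cc(C)oc3c2)cn1` gives 22.3 10^-6 cm/s.
Compound 2 `COc1cnc(NC(=O)c2cc(Oc3cnc(C(=O)N(C)C)cn3)c3cc(C)oc3c2)cn1` gives 15.8 10^-6 cm/s.

Within the data shown here, compound 2 holds the lower of the two numbers, and the only neighbour is compound 1, whose step a 1.4-fold lower number from compound 1 to compound 2 (0.15 log units; within the scatter) is within the scatter. Compound 3 `CCc1cnc(NC(=O)c2cc(Oc3cnc(C(=O)N(C)C)cn3)c3cc(C)oc3c2)cn1` differs from compound 2 by ethyl in place of methoxy on an aromatic carbon. Among the measured compounds shown here, the only step that bears on it is the one from methyl to methoxy at the same place, a 1.4-fold lower number from compound 1 to compound 2 (0.15 log units; within the scatter), which was small. The change to ethyl is therefore expected to give at most a modest step in this assay, a 1.3-fold higher number from compound 2 to compound 3 (0.10 log units; within the scatter), if any beyond the scatter. Compound 3 is estimated at 20 10^-6 cm/s, with a range from 12 10^-6 cm/s to 32 10^-6 cm/s.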

Compound 3, apparent permeability: 23.7 10^-6 cm/s
The estimate for compound 3 lay 1.2-fold (0.07 log units) below the measured number; the measured number falls inside the stated range.
By their numbers in this assay, from the lowest: compounds 2, 1 and 3 (each within the scatter of the next).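

In this assay, replacing methoxy with ethyl gives a 1.5-fold higher number from compound 2 to compound 3 (0.18 log units; within the scatter), and extending methyl to ethyl gives a 1.1-fold higher number from compound 1 to compound 3 (0.03 log units; within the scatter). Neither change separates the compounds, so methyl, methoxy and ethyl at this place read alike within the scatter. No measurement bears on why these three read alike.

Still open, on these data alone, is whether an amine, a carboxylic acid or a longer chain at this place would give a step beyond the scatter. The compounds shown also leave open whether this reading holds with changes elsewhere on the shared core.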